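Swapping Methoxy for Amino on the Distal Ring

A few compounds are considered here, and "the series" means these few. Any claim that something is new, unique, unknown or untested is made for them only; others in the source may bear on it.

Compound 3 `CC[C@H](C)[C@H](N)CN(C(=O)[C@@H]1C[C@H]1c1ccccc1)c1ccc(-c2ccc(OC)cc2)cc1` gives the lowest number of the three compounds measured in a functional assay for agonist activity at G protein-coupled receptor 88 (Homo sapiens), read by HTRF and cAMP accumulation (a higher number here means that more compound is needed for the effect, a lower number that less compound is needed), with compound 3 at 120 nM. Its nearest neighbour, compound 2 `COc1ccc(-c2ccc(N(C[C@@H](N)CC(C)C)C(=O)[C@@H]3C[C@H]3c3ccccc3)cc2)cc1`, gives 330 nM; the step of a 2.8-fold lower number from compound 2 to compound 3 (0.44 log units; beyond the scatter) joins these two, the change being sec-butyl in place of isobutyl on a saturated chain carbon bound to an amine nitrogen and a saturated chain carbon. Compound 1 `CC[C@H](C)[C@H](N)CN(C(=O)[C@@H]1C[C@H]1c1c(F)cccc1F)c1ccc(-c2ccccc2)cc1` gives 11000 nM; it differs from compound 3 in two places at once, so its value serves only as a distant point of comparison. Compound 4 `CC[C@H](C)[C@H](N)CN(C(=O)[C@@H]1C[C@H]1c1ccccc1)c1ccc(-c2ccc(N)cc2)cc1` differs from compound 3 in a single place: amino in place of methoxy on an aromatic carbon. For the measured compounds named here, no measured step bears on this position: the one step at hand, a 2.8-fold lower number from compound 2 to compound 3 (0.44 log units; beyond the scatter), concerns the chain carbon carrying the amine and says nothing about the group on the aromatic ring. The account therefore expects for compound 4 a number close to that of compound 3, the estimated shift a 1.7-fold higher number from compound 3 to compound 4 (0.22 log units; within the scatter) remaining within the usual scatter in either direction. The estimate for compound 4 in this assay is 200 nM, with a range from 60 nM to 650 nM.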

Compound 4, half-maximal effective concentration: 320 nM
Estimate against measurement, compound 4: 1.6-fold (0.20 log units) below, and the stated range covers the measured number.
By their numbers in this assay, from the lowest: compound 3; then compounds 4 and 2 (each within the scatter of the next); then compound 1.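

With a 2.7-fold higher number from compound 3 to compound 4 (0.43 log units; beyond the scatter) in this assay, the change from 4-methoxyphenyl to 4-aminophenyl is a modest step but lies beyond the scatter, so this aromatic carbon, para to a large group, does respond to the group it carries. The change is also tolerated to a degree, since compound 4 keeps a value of 320 nM with amino in place of methoxy, a group with one heavy atom and one hydrogen-bond donor replacing one with two heavy atoms and none. No measurement at hand speaks to what lies behind this step.

This single pair cannot separate the hydrogen-bond donor that enters from the carbon that leaves, and a hydroxyl, a methyl or a dimethylamino group at the same place would be needed to tell those two differences apart. The compounds shown also leave open whether the step from methoxy to amino keeps its size with the isobutyl chain of compound 2 in place of the sec-butyl chain.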